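Taking the Hydroxy Off Compound 3

The source may report more compounds than this note shows. Statements on the series, on what has been measured and on what is new or still open speak of the compounds shown alone.

Compound 1 `COc1cccc(CNCc2c(C(=O)O)n(Cc3ccc(O)cc3)c3cc(C(C)C)ccc23)c1`: 7080 nM
Compound 2 `COc1cccc(CNCc2c(C(=O)O)n(Cc3ccc(C)cc3)c3cc(C(C)C)ccc23)c1`: 5920 nM
Compound 3 `COc1cccc(CNCc2c(C(=O)O)n(Cc3ccc(O)cc3)c3ccccc23)c1`: > 50000 nM (a limit, not a number)

These three compounds were tested in a functional assay on Bel-7402 cells (Homo sapiens) for antiproliferative activity, read by MTT assay, with a stated time of 72 h; on this read-out lower numbers stand for stronger inhibition and higher numbers for weaker inhibition. Compound 3 stands at the limit of > 50000 nM in this assay, at which 1 of the 3 values shown sits, so its result is a limit of the assay and not a number.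

Compound 4 `COc1cccc(CNCc2c(C(=O)O)n(Cc3ccccc3)c3ccccc23)c1` differs from compound 3 in one place: hydrogen in place of hydroxy on an aromatic carbon. In words, this is hydrogen in place of hydroxy on an aromatic carbon, which turns 4-hydroxybenzyl into benzyl.

For the measured compounds named here, two measured steps bear on this. The closer one is a 1.2-fold lower number from compound 1 to compound 2 (0.08 log units; within the scatter), where methyl takes the place of the same hydroxy. That swap did not move the result beyond the scatter, although methyl is not hydrogen, so the parallel is imperfect. The other is an at least 7.0-fold higher number from compound 1 to compound 3 (0.84 log units; beyond the scatter), where hydrogen replaces isopropyl at a different place. Compound 4 lacks the isopropyl too, so it shares this feature with compound 3.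

In this assay, no step beyond the scatter is therefore expected in either direction, and another limit is a likely outcome. The estimated step is a step that the limit leaves unreadable from compound 3 to compound 4. Compound 4 is expected at about 55000 nM, with an estimated range from 20000 nM to 150000 nM.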

Compound 4, half-maximal inhibitory concentration: > 50000 nM
Compound 4 was reported as a limit; the forecaster's own chance of this, stated with the estimate: 70%; the middle value is on the limit's open side.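

In this assay compound 4 gives > 50000 nM, which is a limit of the assay and not a number. Compound 3 and compound 4 thus both stand at a limit, so no step between them can be read: the limit of > 50000 nM in this assay, at which 2 of the 4 values shown sit.

The compounds shown leave open whether swapping 4-hydroxybenzyl for benzyl changes the result at all when the isopropyl is absent.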